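This account rests on a few compounds, and the source may have more. Where it says the series, first, only, none or still open, it means among the compounds named here.

Series notes, serine protease 1 inhibition.

Three compounds of the shared core have numbers in an assay on isolated protein for inhibition of serine protease 1 (Bos taurus); on this read-out lower numbers stand for stronger inhibition and higher numbers for weaker inhibition. Compound 1 `CC(=N)N1CCC(Oc2ccc3nc(C)n(Cc4ccc5ccc(C(=N)N)cc5c4)c3c2)CC1` gives 18 nM. Compound 2 `CC(=N)N1CCC(Oc2ccc3c(c2)nc(CCC(=O)O)n3Cc2ccc3ccc(C(=N)N)cc3c2)CC1` gives 14 nM. Compound 3 `CCC(C)c1nc2ccc(OC3CCN(C(C)=N)CC3)cc2n1Cc1ccc2ccc(C(=N)N)cc2c1` gives 10 nM, the lowest of the three, though its gaps to compound 1 and to compound 2 both lie within the scatter, so no order among them can be read.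

Within the data shown here, the one measured step that touches the same position is a 1.8-fold lower number from compound 1 to compound 3 (0.26 log units; within the scatter), a change in the size of the alkyl group that left the number essentially unchanged.

Compound 4 `CCCCc1nc2ccc(OC3CCN(C(C)=N)CC3)cc2n1Cc1ccc2ccc(C(=N)N)cc2c1` differs from compound 3 by butyl in place of sec-butyl on an aromatic carbon. This is a rearrangement of the same four carbons at a position where, going from compound 1 to compound 3, even the larger change of adding three carbons stayed within the scatter. No step beyond the scatter is therefore expected here; the estimated step of no change at the digits printed from compound 3 to compound 4 (within the scatter) is meant as no real change.

Compound 4 is expected to give about 10 nM, in the range 5 nM to 22 nM.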

Compound 4, inhibition constant: 5.7 nM
Compound 4: middle estimate off by 1.8-fold (0.24 log units), on the high side; the range from low to high includes it.
By their numbers in this assay, from the lowest: compounds 4, 3, 2 and 1 (each within the scatter of the next, the first and the last beyond it).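

In this assay, among these compounds, butyl in place of sec-butyl (a 1.8-fold lower number from compound 3 to compound 4 (0.24 log units; within the scatter)) shows that rearranging the same four carbons at this position gives no step that can be read. Among the compounds shown here, the comparison with the methyl compound (a 3.2-fold lower number from compound 1 to compound 4 (0.50 log units; beyond the scatter)) is the first step at this position to pass the scatter, so the alkyl group here can move the number modestly, although the sec-butyl step from the same starting point stayed within it. No evidence bears on why this step occurs.

Compound 3 and compound 4 stay within the scatter of each other, so the shown compounds do not separate branched from straight chains. As far as these compounds go, whether a longer chain such as hexyl would extend the trend, or an amine at the chain end would keep it, remains open.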